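Acetyl in place of methoxy, second placement

The source may report more compounds than this note shows. Statements on the series, on what has been measured and on what is new or still open speak of the compounds shown alone.

Of the compounds shown here, three of one series have been measured in an ADME assay on the whole organism with Oryza sativa as the target, tested at 10 uM; a lower number here means a stronger effect, a higher number a weaker effect of the compound at the concentration tested. Compound 1 `COc1ccccc1NC(=O)N[C@H](C)c1ccccc1` gives 96% in this assay. Compound 3 `CC(=O)c1ccccc1NC(=O)N[C@H](C)c1ccccc1` gives 89% in this assay. Compound 2 `COc1cccc(NC(=O)N[C@H](C)c2ccccc2)c1` gives 70% in this assay, the lowest of the three, with the nearest other value that of compound 3 and the furthest that of compound 1, both separated from it beyond the scatter.

Compound 1 and compound 3 differ in one place: acetyl in place of methoxy on an aromatic carbon. This change gave a number 7 percentage points lower from compound 1 to compound 3 (within the scatter).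

Compound 2 has the same atoms as compound 1, joined differently; the difference between the two cores is not broken down here.

Compound 4 `CC(=O)c1cccc(NC(=O)N[C@H](C)c2ccccc2)c1` is not yet measured. From compound 2 it differs in one place: acetyl in place of methoxy on an aromatic carbon. This is the same kind of change as that from compound 1 to compound 3, but not the same: there the place was ortho to a large group, here it is meta to a large group. The change occurs twice in all among the compounds shown.

The expectation for compound 4 rests on one measured step only, that from compound 1 to compound 3, a number 7 percentage points lower from compound 1 to compound 3 (within the scatter), together with the position of compound 2 at 70%. The step is expected to be a number 6 percentage points lower from compound 2 to compound 4 (within the scatter). For compound 4 the estimate in this assay is 64%, expected to lie between 46% and 82%.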

Compound 4, a percentage reported as activity, at one concentration (the size of the read-out at that concentration, not a potency): 73%
Beside the measured number, compound 4's estimate is 9 percentage points below it; low and high end bracket the measured number.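

In this assay, among the compounds shown here, acetyl in place of methoxy, here meta to a large group, gives a number 3 percentage points higher from compound 2 to compound 4 (within the scatter), so on this core too the exchange leaves no step that can be told from the usual scatter. Set side by side, the two steps do not differ, and the exchange reads the same on both cores: the same change on two cores in this assay, a number 7 percentage points lower (within the scatter) from compound 1 to compound 3 and a number 3 percentage points higher (within the scatter) from compound 2 to compound 4, 10 percentage points apart, within the scatter of two such steps This supports carrying the exchange between these two cores as a step too small to resolve in this read-out, but it does not show that the two groups are equivalent, that a small real step is absent on either core, or that the same would hold on any third core, and two steps at one tested concentration are a narrow basis for a rule.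

The compounds shown leave open whether the read-out at this place on the ring responds to groups of another kind, such as an amine, a carboxylic acid or a longer chain in place of the methoxy or acetyl. They also leave open whether the exchange would stay within the scatter in any other assay, as this series is compared here in a single one.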